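The compounds below may be only part of what the source reports. "The series", "measured", "known", "first", "only" and "open" are said of these compounds alone.

Measured so far in a functional assay on PC-3 cells (Homo sapiens) for inhibition, read by sulforhodamine B assay, with a stated time of 48 h; a lower number here means that less compound is tolerated, a higher number that more compound is tolerated:

Compound 1 `COc1cc(C)cc(-c2nn(CC#N)cc2-c2ccc(-c3cccc(C(C)=O)c3)nc2)c1` gives > 100000 nM, which is a limit of the assay rather than a number.
Compound 2 `Cc1cc(O)cc(-c2nn(CC#N)cc2-c2ccnc(-c3ccc(Oc4ccccc4)cc3)c2)c1` gives 62000 nM.
Compound 3 `COc1cc(C)cc(-c2nn(CC#N)cc2-c2ccnc(-c3ccc(N(C)C)cc3)c2)c1` gives > 100000 nM, again a limit of the assay and not a number.

Compound 3 therefore stands at the limit of > 100000 nM in this assay, at which 2 of the 3 values shown sit, so its true value is not pinned down; only compound 2 gives a number in this assay, and that number lies not far from the same limit. Within the data shown here, no pair of measured compounds differs in a single place, so no measured step is available to lean on.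

Compound 4 `Cc1cc(O)cc(-c2nn(CC#N)cc2-c2ccnc(-c3ccc(N(C)C)cc3)c2)c1` differs from compound 3 in one place: hydrogen in place of methyl on an oxygen on an aromatic ring, so that the methoxy becomes a hydroxy. With compound 3 sitting at the limit, the step from compound 3 to compound 4 is expected to be small or none beyond the scatter, an at least 1.1-fold lower number from compound 3 to compound 4 (0.04 log units; that floor lies within the scatter). Compound 4 is thus expected to give about 90000 nM, within a range of 30000 nM to 300000 nM, with a fair chance that this assay again reports only a limit.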

Compound 4, concentration lethal to 50% of the cells: > 100000 nM
Compound 4 gave a limit, no number (the forecaster's own chance of this, stated with the estimate: 50%); middle value at least 1.1-fold (0.04 log units) from the limit.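

The change from methoxy to hydroxy cannot be sized in this assay, because compound 3 and compound 4 both give a limit of the assay and not a number: the limit of > 100000 nM in this assay, at which 3 of the 4 values shown sit.

Even so, the hydroxy on its own does not bring the dimethylamino series to a readable number at this position. With the hydroxy kept, changing phenoxy to dimethylamino on an aromatic carbon gives an at least 1.6-fold higher number from compound 2 to compound 4 (0.20 log units; that floor lies within the scatter), so this is only a lower bound on the step, and the true size could be larger.

On these data alone, how far compound 3 and compound 4 truly lie past the limit stays open, and so does whether this change has any effect at all. Also open, as far as these compounds go, is whether an amino group or a longer chain such as ethoxy, in place of the hydroxy, would give a readable number.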